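Bromo for methoxy on a shared core: cytotoxicity notes

A few compounds are considered here, and "the series" means these few. Any claim that something is new, unique, unknown or untested is made for them only; others in the source may bear on it.

Measured compounds:
- Compound 1 `C=C1C[C@]23C[C@@]1(O)CC[C@@H]2c1cccc(C)c1[C@@H]3Cn1cc(-c2ccc(OC)cc2)nn1` in a functional assay on SMMC-7721 cells (Homo sapiens) for cytotoxicity, read by MTT assay, with a stated time of 4 days; on this read-out higher numbers stand for weaker inhibition and lower numbers for stronger inhibition: > 20000 nM.
- Compound 2 `COc1ccc(-c2cn(C[C@H]3c4c(ccc(OS(=O)(=O)c5ccc(C)cc5)c4C)[C@@H]4CC[C@@]5(C)C[C@]43CC5=O)nn2)cc1` in this assay: > 20000 nM.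
- Compound 3 `C=C1C[C@]23C[C@@]1(O)CC[C@@H]2c1cccc(C)c1[C@@H]3Cn1cc(-c2ccc(Br)cc2)nn1` in this assay: > 20000 nM.

The value of compound 1 is a limit of the assay, not a number. The value of compound 2 is likewise a limit. The value of compound 3 is again a limit. All three sit at the same limit (the limit of > 20000 nM in this assay, at which 3 of the 3 values shown sit), so none of them can be ordered against another.

From compound 1 to compound 3 the change is bromo in place of methoxy on an aromatic carbon. The step that the two limits leave unreadable from compound 1 to compound 3 cannot be read, since both ends are limits.

The difference between the core of compound 1 and the core of compound 2 is not broken down here.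

Compound 4 `Cc1ccc(S(=O)(=O)Oc2ccc3c(c2C)[C@H](Cn2cc(-c4ccc(Br)cc4)nn2)[C@@]24CC(=O)[C@@](C)(CC[C@@H]32)C4)cc1` is not yet measured. Against compound 2 it carries the change (bromo in place of methoxy on an aromatic carbon), the same change as the one from compound 1 to compound 3, at the same place.

For compound 4 in this assay the step that the limit leaves unreadable from compound 2 to compound 4 is expected to be small or unreadable, resting on the fact that the only shown instance of this change, from compound 1 to compound 3, left both ends at the limit (the limit of > 20000 nM in this assay, at which 3 of the 3 values shown sit). Compound 4 is therefore expected to come out near 30000 nM, most likely again as a limit rather than a number, within an estimated range of 10000 nM to 100000 nM.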

Compound 4, half-maximal inhibitory concentration: > 20000 nM
Compound 4: no number, only a limit (the forecaster's own chance of this, stated with the estimate: 75%); the middle value is on the limit's open side.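

No new step can be read between compound 2 and compound 4, since both values are limits and not numbers: the limit of > 20000 nM in this assay, at which 4 of the 4 values shown sit.

The compounds shown leave open whether 4-methoxyphenyl to 4-bromophenyl makes any difference in this assay, and which structure, if any, would give a number there rather than a limit.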